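The source may report more compounds than this note shows. Statements on the series, on what has been measured and on what is new or still open speak of the compounds shown alone.

In an ADME assay on the whole organism (blood, Mus musculus, strain C57BL/6) for pharmacokinetics, read by HPLC, with a stated time of 4 h, at a dose of 2 mg/kg by the intraperitoneal route (a lower number here means less compound in the circulation, a higher number more compound in the circulation at the dose given), the study has two numbers and one result without a number. Compound 1 `CN1CCN(S(=O)(=O)c2c(Cl)ccc(NC(=O)Nc3cccc(Cl)c3Cl)c2O)CC1` gives 303 ng.h/mL there and compound 2 `CCN1CCN(S(=O)(=O)c2c(Cl)ccc(NC(=O)Nc3cccc(F)c3Cl)c2O)CC1` gives 189 ng.h/mL in the same measurement, two values within the usual scatter of each other. Compound 3 `O=C(Nc1ccc(Cl)c(C(=O)N2CCCC2)c1O)Nc1cccc(F)c1Cl` returns "below limit of detection" (no number reported) as its result, which is a statement and not a number. Among the measured compounds shown here, compound 1 thus stands level with compound 2 and apart from compound 3, the one entry without a number.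

Compound 4 `CCS(=O)(=O)c1c(Cl)ccc(NC(=O)Nc2cccc(Cl)c2Cl)c1O` keeps the core of compound 1 and differs in one place, with ethyl in place of 4-methylpiperazin-1-yl on a sulfonyl sulfur and nothing else altered. For the measured compounds named here, no measured pair shows this change on its own, so the expectation rests on little. Compound 3 also lacks 4-methylpiperazin-1-yl, and its result of "below limit of detection" (no number reported) tilts the expectation downward. The estimated step is a 1.5-fold lower number from compound 1 to compound 4 (0.18 log units; within the scatter) and is expected to point downward without leaving the scatter, although a larger fall remains possible. In this assay the estimate for compound 4 is 200 ng.h/mL with an expected range from 40 ng.h/mL to 1000 ng.h/mL as its two ends.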

Compound 4, area under the concentration-time curve: 256 ng.h/mL
Estimate against measurement, compound 4: 1.3-fold (0.11 log units) below; the range from low to high includes it.
By their numbers in this assay, from the lowest: compounds 2, 4 and 1 (each within the scatter of the next).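

In this assay, replacing the 4-methylpiperazin-1-yl group on the sulfonyl sulfur with ethyl gives a 1.2-fold lower number from compound 1 to compound 4 (0.07 log units; within the scatter), so this pair stands level and the exchange leaves no change that can be told from the scatter. Among the compounds shown here, the result is the first direct reading at this place: a measurable number in the circulation does not require the six-membered ring or its 2 hetero atoms on the sulfonyl sulfur, as compound 4, with ethyl and no ring, gives 256 ng.h/mL at the same dose and read-out. Nothing measured here explains why the two compounds stand level, and no supporting data bear on this result.

On these data alone, the change is seen in this one pair only, so it remains open whether ethyl and 4-methylpiperazin-1-yl would also stand level on a different core. Also open, as far as these compounds go, is what methyl, a longer chain such as butyl, a morpholine ring or a group carrying a carboxylic acid on the sulfonyl sulfur would give in this assay at this dose.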